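The source may hold more compounds than are shown below. What is called first, only, known or untested is meant among the compounds shown, and "the series" means these compounds.

Compound 2, `COc1ccc(-c2nnsc2SCC(=O)Nc2ccccc2Br)cc1`, is the starting point of this step. In an ADME assay on MT4 cells (Homo sapiens) for cytotoxicity (a lower number here means that less compound is tolerated, a higher number that more compound is tolerated), compound 2 gives > 286000 nM, which is a limit of the assay and not a number. Two measured neighbours differ from compound 2 in one place: compound 1, `COc1ccc(-c2nnsc2SCC(=O)Nc2ccccc2[N+](=O)[O-])cc1`, and compound 3, `CCOC(=O)c1ccc(NC(=O)CSc2snnc2-c2ccc(OC)cc2)c(Br)c1`. In this assay compound 1 gives >= 280000 nM, also a limit. In this assay compound 3 gives > 245000 nM, again a limit. For the measured compounds named here, all three values so far sit at a limit, so compound 2 stands among them without a number of its own.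

Compound 4, `O=C(CSc1snnc1-c1ccccc1)Nc1ccccc1Br`, is the compound still to be measured. It differs from compound 2 in one place: hydrogen in place of methoxy on an aromatic carbon

The measured steps that bear on this change are a step that the two limits leave unreadable from compound 1 to compound 2 and a step that the two limits leave unreadable from compound 2 to compound 3. Neither can be read, as both ends of each step are limits, shown by the limit of > 245000 nM in this assay, at which 1 of the 3 values shown sits, the limit of > 286000 nM in this assay, at which 1 of the 3 values shown sits, and (the limit of >= 280000 nM in this assay, at which 1 of the 3 values shown sits). With every value at a limit, the step expected in this assay is an at least 1.0-fold lower number from compound 2 to compound 4 (0.00 log units; that floor lies within the scatter), none beyond the scatter. Compound 4 is therefore expected to give about 280000 nM, within a range from 200000 nM to 400000 nM, and most likely to return only a limit again.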

Compound 4, half-maximal cytotoxic concentration: > 307000 nM
Compound 4 gave a limit, no number; the forecaster's own chance of this, stated with the estimate: 85%; middle value at least 1.0-fold (0.03 log units) from the limit.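

In this assay compound 4 gives > 307000 nM, which is a limit of the assay and not a number. For the compounds shown here, compound 2 also stands at a limit, so no step between compound 2 and compound 4 can be read. The compounds shown leave open whether changing 4-methoxyphenyl to phenyl alters cytotoxicity at all, and at what concentration any of these four compounds becomes cytotoxic.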